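From anilino to 4-methylpiperidin-1-yl on compound 2

The compounds below may be only part of what the source reports. "The series", "measured", "known", "first", "only" and "open" are said of these compounds alone.

Compound 1 `Cc1ccc(Nc2nc(Cl)nc3c2ncn3Cc2ccc(C(=O)Nc3ccccc3N)cc2)cc1`: 860 nM
Compound 2 `Nc1ccccc1NC(=O)c1ccc(Cn2cnc3c(Nc4ccccc4)nc(Cl)nc32)cc1`: 4180 nM
Compound 3 `Nc1ccccc1NC(=O)c1ccc(Cn2cnc3c(Nc4ccc(-c5ccccn5)cc4)nc(Cl)nc32)cc1`: 30100 nM

These three compounds share one core and differ only in what the anilino ring carries. In a functional assay on HepG2 cells (Homo sapiens) for antiproliferative activity, read by CCK-8 assay, with a stated time of 72 h (a lower number here means a stronger inhibitor, a higher number a weaker inhibitor), compound 2 gives 4180 nM, the middle of the three numbers, with compound 1 lower and compound 3 higher.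

Compound 4 `CC1CCN(c2nc(Cl)nc3c2ncn3Cc2ccc(C(=O)Nc3ccccc3N)cc2)CC1` goes further and replaces the whole group, with 4-methylpiperidin-1-yl in place of anilino on an aromatic carbon.

The measured steps bear on this only indirectly, as each one alters a substituent and none replaces the anilino group itself. Losing the methyl gives a 4.9-fold higher number from compound 1 to compound 2 (0.69 log units; beyond the scatter), a modest step. Adding pyridin-2-yl gives a 7.2-fold higher number from compound 2 to compound 3 (0.86 log units; beyond the scatter), also modest, and the widest gap is large: a 35-fold higher number from compound 1 to compound 3 (1.54 log units; beyond the scatter).

Compound 4 carries a methyl, as compound 1 does, and the step of a 4.9-fold higher number from compound 1 to compound 2 (0.69 log units; beyond the scatter) gives a slight lean towards a lower number. Among the compounds with values here, no measured compound shows what happens when the aromatic ring of the anilino group is lost, so the expectation stays loose. The expected change is small, a 1.4-fold lower number from compound 2 to compound 4 (0.14 log units; within the scatter), and is not expected to lie beyond the scatter. For compound 4 the estimated value is 3000 nM, with an expected range from 600 nM to 15000 nM.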

Compound 4, half-maximal inhibitory concentration: 5180 nM
Beside the measured number, compound 4's estimate is 1.7-fold (0.24 log units) below it; the measured number falls inside the stated range.
By their numbers in this assay, from the lowest: compound 1; then compounds 2 and 4 (each within the scatter of the next); then compound 3.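

In this assay, the anilino group gives way to 4-methylpiperidin-1-yl with a 1.2-fold higher number from compound 2 to compound 4 (0.09 log units; within the scatter), so the number does not separate these two groups, although a six-membered non-aromatic ring replaces an aromatic ring of carbon only and the entering group has 0 hydrogen-bond donors against 1 for the leaving group. Within the data shown here, the earlier compounds changed only what the anilino ring carried, so this is the first sign that the aromatic ring and the donor hydrogen of that group are not both required to stay at this level in this cell assay. Compound 4 also carries a methyl, yet the replacement of (4-methylphenyl)amino gives a 6.0-fold higher number from compound 1 to compound 4 (0.78 log units; beyond the scatter), and no information here explains any of these steps.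

From the compounds shown here alone, the plain piperidin-1-yl group lies outside this set, so the part played by the methyl on the new ring remains open, as does the outcome with morpholin-4-yl or an open-chain amine such as diethylamino at this place. Also open, going by these compounds, is how a carboxylic acid or a hydroxyl group in place of the methyl of compound 1 would fare.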